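A few compounds are considered here, and "the series" means these few. Any claim that something is new, unique, unknown or untested is made for them only; others in the source may bear on it.

Going by the values given here, in a functional assay on A549 cells (Homo sapiens) for inhibition, read by MTT assay, with a stated time of 48 h (a lower number here means a stronger inhibitor, a higher number a weaker inhibitor), compound 2 `COc1cc(-c2nccn3cc(-c4ccc5[nH]ccc5c4)nc23)cc(OC)c1OC` gives 154 nM, the lower of the two numbers so far, while compound 1 `COc1cc(-c2nccn3cc(-c4ccc(Cl)cc4)nc23)cc(OC)c1OC` gives 7290 nM. Compound 3 `COc1cc(-c2nccn3cc(-c4ccc([N+](=O)[O-])cc4)nc23)cc(OC)c1OC` has not been measured, and its difference from compound 2 is this: 4-nitrophenyl in place of 1H-indol-5-yl on an aromatic carbon. Among the compounds with values here, one measured step bears on the change: a 47-fold lower number from compound 1 to compound 2 (1.68 log units; beyond the scatter), a large step beyond the scatter, in which 1H-indol-5-yl took the place of 4-chlorophenyl. Compound 3 also gives up 1H-indol-5-yl for a substituted phenyl, so a large step to a higher number is expected, estimated as a 23-fold higher number from compound 2 to compound 3 (1.36 log units; beyond the scatter). For compound 3 the expected value is 3500 nM, within an estimated range of 700 nM to 15000 nM.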

Compound 3, half-maximal inhibitory concentration: > 10000 nM
Compound 3: no number, only a limit (the forecaster's own chance of this, stated with the estimate: 5%); middle value at least 2.8-fold (0.45 log units) away from the limit.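

Compound 3 has only a limit and not a number: the limit of > 10000 nM in this assay, at which 1 of the 3 values shown sits. With 4-nitrophenyl on this aromatic carbon, the result is an at least 64-fold higher number from compound 2 to compound 3 (1.81 log units; beyond the scatter), so a second substituted phenyl, and not only 4-chlorophenyl, falls far short of 1H-indol-5-yl. Nitro in place of chloro gives an at least 1.3-fold higher number from compound 1 to compound 3 (0.13 log units; that floor lies within the scatter), a floor that leaves the distance between these two phenyl groups unsettled.

The compounds shown leave open whether the fused second ring or the hydrogen-bond donor of 1H-indol-5-yl carries the difference. A 4-aminophenyl group, an amine on a single ring, would help separate the two.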